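Compound 2 to compound 3: iodo for phenoxy

The compounds below may be only part of what the source reports. "The series", "measured", "known", "first", "only" and "open" are said of these compounds alone.

Among the measured compounds shown here, in a functional assay on DU-145 cells (Homo sapiens) for inhibition, read by trypan blue exclusion, with a stated time of 96 h (a higher number here means a weaker inhibitor of growth, a lower number a stronger inhibitor of growth), compound 2 (`O=C(/C(=C\c1ccc(Oc2ccccc2)cc1)Sc1ccc(Br)cc1)c1ccc(Br)cc1`) gives 50000 nM, the higher of the two numbers so far and beyond the scatter from compound 1 (`O=C(/C(=C\c1ccc(F)cc1F)Sc1ccc(Br)cc1)c1ccc(Br)cc1`), which gives 1000 nM. Compound 3 (`O=C(/C(=C\c1ccc(I)cc1)Sc1ccc(Br)cc1)c1ccc(Br)cc1`) carries iodo in place of phenoxy on an aromatic carbon. For the measured compounds named here, no step in one place has been measured, so the expectation rests on compound 1 at 1000 nM, which also lacks phenoxy. A large fall in the number, towards stronger inhibition, is expected: a 25-fold lower number from compound 2 to compound 3 (1.40 log units; beyond the scatter). For compound 3 the estimated value is 2000 nM, with a range of 400 nM to 10000 nM.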

Compound 3, concentration for 50% growth inhibition: 1000 nM
Beside the measured number, compound 3's estimate is 2.0-fold (0.30 log units) above it; the range from low to high includes it.
By their numbers in this assay, from the lowest: compounds 1 and 3 (each within the scatter of the next); then compound 2.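

In this assay, among the compounds shown here, iodo in place of phenoxy, on an aromatic carbon para to a large group, gives a 50-fold lower number from compound 2 to compound 3 (1.70 log units; beyond the scatter) as the first single-place reading at this position. 4-Iodophenyl in place of 2,4-difluorophenyl gives no change at the digits printed from compound 1 to compound 3 (within the scatter) and so does not separate these two groups on the shared core. No evidence here explains the difference between phenoxy and iodo.

On these data alone, it remains open whether methoxy, an amine or a carboxylic acid on this carbon would read like compound 3 or like compound 2.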